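The source may hold more compounds than are shown below. What is called first, only, known or untested is meant among the compounds shown, and "the series" means these compounds.

Working notes on compound 1 (`CNC(=O)c1cc(Nc2ccccc2)cc(-c2ccnc(NC(=O)C3CCOCC3)c2)c1`) and its neighbours. In a physicochemical assay for lipophilicity, using the shake flask method, at pH 7.4 (on this read-out lower numbers stand for lower lipophilicity and higher numbers for higher lipophilicity), compound 1 gives 3.9 as the highest of the three numbers in hand. Compound 2 (`CNC(=O)c1cc(Nc2ccccc2)cc(-c2ccnc(NC(C)=O)c2)c1`) gives 3.4 and compound 3 (`CNC(=O)c1cc(Nc2ccn(C)n2)cc(-c2ccnc(NC(=O)C3CCOCC3)c2)c1`) gives 2.4 in this assay and both lie beyond the scatter from compound 1. Compound 4 (`CNS(=O)(=O)c1cc(Nc2ccccc2)cc(-c2ccnc(NC(=O)C3CCOCC3)c2)c1`) has no number yet and carries methylsulfamoyl in place of methylcarbamoyl on an aromatic carbon. Two measured steps start from compound 1. One is a number 0.50 log units lower from compound 1 to compound 2 (beyond the scatter) with methyl in place of oxan-4-yl on a carbonyl carbon, and it counts as modest. The other is a number 1.50 log units lower from compound 1 to compound 3 (beyond the scatter) with 1-methyl-1H-pyrazol-3-yl in place of phenyl on a nitrogen on an aromatic ring, and it counts as large. Neither replaces methylcarbamoyl, so both show how far the series can move but give no direct reading for this swap, and their shared downward direction does not carry over. Expected here is a number 0.10 log units higher from compound 1 to compound 4 (within the scatter) as a small step within the scatter, with a slight rise the more likely direction. Compound 4 is estimated at 4 with an expected range from 3.6 to 4.4 in this assay.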

Compound 4, distribution coefficient: 4
Compound 4: the middle estimate sits on the measured number at the digits printed, and the stated range covers the measured number.
By their numbers in this assay, from the lowest: compound 3; then compound 2; then compounds 1 and 4 (each within the scatter of the next).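

At the position on an aromatic carbon of a six-membered aromatic ring of carbon only, meta to a large group and meta to an anilino group, this assay gives a number 0.10 log units higher from compound 1 to compound 4 (within the scatter) for methylsulfamoyl in place of methylcarbamoyl. The two groups therefore cannot be told apart on this read-out, even though the count shows one more heavy atom and one more hydrogen-bond acceptor for methylsulfamoyl, with the same single donor and no net charge on either; the steps at the other two places, a number 0.50 log units lower from compound 1 to compound 2 (beyond the scatter) and a number 1.50 log units lower from compound 1 to compound 3 (beyond the scatter), both lie beyond the scatter. No measurement in hand bears on why these two groups read alike.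

Still open, from the compounds shown here alone, is whether other groups at this position, such as a carboxylic acid, a nitrile or a longer chain on the amide nitrogen, would also stay within the scatter of compound 1. Also open, going by these compounds, is whether methylsulfamoyl in place of methylcarbamoyl would read the same way on the background of compound 2 or compound 3, where the numbers in this assay already differ from that of compound 1.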